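The source may hold more compounds than are shown below. What is called first, only, known or untested is meant among the compounds shown, and "the series" means these compounds.

Going by the values given here, compound 1 `Cc1nc(N2CCC(N3CCCC3=O)CC2)nc2ccc(NC(=O)/C=C/c3ccc(Cl)cc3)cc12` is the only member of this set with a number in hand. In an ADME assay on microsomes from liver (Homo sapiens) for metabolic stability, with a stated time of 30 min (a lower number here means that less of the compound is left, a higher number that more of the compound is left), compound 1 gives 50%. Nothing else has been measured. Compound 2 `C/C(=C\C(=O)Nc1ccc2nc(N3CCC(N4CCCC4=O)CC3)nc(C)c2c1)c1ccc(OC(F)(F)F)cc1` was entered into the same assay, and in this assay compound 2 gives "not determined" (no result reported), so it offers no comparison.

Compound 3 `Cc1nc(N2CCC(N3CCCC3=O)CC2)nc2ccc(NC(=O)/C=C/c3ccc(OC(F)(F)F)cc3)cc12` differs from compound 1 in one place: trifluoromethoxy in place of chloro on an aromatic carbon. Among the compounds with values here, no step between two measured compounds is available to calibrate what such a replacement does in this assay, so the expectation rests on compound 1 alone.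

Given that, the change from compound 1 to compound 3 is expected to leave the percent remaining essentially where it is, with the expected step of no change at the digits printed from compound 1 to compound 3 (within the scatter) falling within the usual scatter rather than marking a clear move in either direction. Compound 3 is therefore estimated to give 50% in this assay, with a plausible range from 30% to 70%.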

Compound 3, percent of the compound remaining: 76%
Compound 3: the middle estimate sits 26 percentage points below what was measured; measured number outside the range, above it.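

Going by these compounds alone, the exchange of 4-chlorophenyl for 4-(trifluoromethoxy)phenyl gives the first readable step in this set: this assay shows a number 26 percentage points higher from compound 1 to compound 3 (beyond the scatter). The read-out therefore responds to the group on this aromatic carbon, para to a large group, and here the swap of a single chlorine for the five heavy atoms of trifluoromethoxy goes with more of the compound being left. This rests on one pair on one shared core, and nothing available accounts for the size or direction of the step.

Steps involving compound 2 cannot be read, so it remains unknown whether the trifluoromethoxy result carries over to a compound that differs elsewhere in the structure. Going by these compounds, it also remains open whether the higher percent remaining is particular to trifluoromethoxy or would also appear with other groups at this position, such as methoxy, trifluoromethyl, a nitrile or an amine.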